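The compounds below may be only part of what the source reports. "The series", "measured", "known", "first", "only" and "open" are said of these compounds alone.

Among the compounds with values here, in a functional assay on BMDM cells (Mus musculus, strain C57BL/6) for inhibition, with a stated time of 2 days (on this read-out higher numbers stand for weaker inhibition and lower numbers for stronger inhibition), compound 2 `CCOC(=O)c1sc(NC(=O)Cn2cc(-c3cccs3)nn2)nc1C` gives 20 nM, the only number in the set so far. Compound 1 `COC(=O)c1ccc(-c2cn(CC(=O)Nc3nc(C)cs3)nn2)cc1` gives > 30000 nM in this assay, which is a limit of the assay and not a number. Hence (the limit of > 30000 nM in this assay, at which 1 of the 2 values shown sits), and compound 2 alone anchors the scale; its value stands well clear of that limit. Compound 3 `CCOC(=O)c1sc(NC(=O)Cn2cc(-c3ccncc3)nn2)nc1C` is not yet measured. It differs from compound 2 by pyridin-4-yl in place of thiophen-2-yl on an aromatic carbon. Within the data shown here, no pair of measured compounds differing in one place is available, so the size of such a change cannot be read from the data, and the expectation rests on the measured value of compound 2 alone. A modest weakening of inhibition, somewhat beyond the scatter, is expected from this exchange of aromatic groups; the expected step is a 5.0-fold higher number from compound 2 to compound 3 (0.70 log units; beyond the scatter). Compound 3 is estimated to give 100 nM in this assay, with a range from 20 nM to 600 nM.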

Compound 3, half-maximal inhibitory concentration: 120 nM
Estimate against measurement, compound 3: 1.2-fold (0.08 log units) below; the range from low to high includes it.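

In this assay, within the data shown here, the exchange of thiophen-2-yl for pyridin-4-yl gives a 6.0-fold higher number from compound 2 to compound 3 (0.78 log units; beyond the scatter), the first size of a change that can be read. On this aromatic carbon of the five-membered aromatic ring with 3 nitrogen, a six-membered aromatic ring therefore carries a modest cost, and compound 3 still gives a measured value rather than a limit of the assay. The data hold no measured property that accounts for this step.

One exchange cannot separate ring size from the identity of the hetero atom, and phenyl or pyridin-3-yl at this place would bear on that question. On these data alone, how a carboxylic acid in place of the ethyl ester would read on the same core also remains open.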